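The source may report more compounds than this note shows. Statements on the series, on what has been measured and on what is new or still open speak of the compounds shown alone.

Measured in a functional assay on Jurkat cells (Homo sapiens) for inhibition, read by MTT assay, with a stated time of 72 h; a lower number here means a stronger inhibitor of growth, a higher number a weaker inhibitor of growth:
compound 1, `CCc1nc(C(=O)OC)nn1-c1ccc(F)cc1`, gives 11000 nM.
compound 2, `COC(=O)c1nc(C(C)C)n(-c2ccc(F)cc2)n1`, gives > 100000 nM, a limit of the assay.
compound 3, `COC(=O)c1nc(-c2ccc[nH]2)n(-c2ccc(C(F)(F)F)cc2)n1`, gives > 100000 nM, a limit of the assay.

Between compound 1 and compound 2 the change is methyl in place of hydrogen on a saturated chain carbon bound to an aromatic carbon and a saturated chain carbon; in this assay it produced an at least 9.0-fold higher number from compound 1 to compound 2 (0.95 log units; beyond the scatter). Compound 4, `CCOC(=O)c1nc(-c2ccc[nH]2)n(-c2ccc(C(F)(F)F)cc2)n1`, is not yet measured and differs from compound 3 by methyl in place of hydrogen on a saturated chain carbon bound to an oxygen next to a carbonyl group. For the measured compounds named here, this is the same kind of change as the one from compound 1 to compound 2, but not the same: there the methyl enters on a saturated chain carbon bound to an aromatic carbon and a saturated chain carbon, here on a saturated chain carbon bound to an oxygen next to a carbonyl group. How the core of compound 3 differs from the core of compound 1 is not broken down here. Compound 3 already stands at the limit of > 100000 nM in this assay, at which 2 of the 3 values shown sit.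

The earlier step weakened growth inhibition, and compound 3 starts where no number was read. The expected step is therefore a step that the limit leaves unreadable from compound 3 to compound 4, because compound 3 sits at the limit of > 100000 nM in this assay, at which 2 of the 3 values shown sit. Compound 4 is estimated at 150000 nM, between 50000 nM and 600000 nM, and is most likely to be reported only as a limit.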

Compound 4, concentration for 50% growth inhibition: > 100000 nM
Compound 4: no number, only a limit; the forecaster's own chance of this, stated with the estimate: 80%; the middle value lies beyond the limit too.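

In this assay compound 4 gives > 100000 nM, a limit of the assay and not a number. Compound 3 also stands at a limit, and no step from compound 3 to compound 4 can be read: the limit of > 100000 nM in this assay, at which 3 of the 4 values shown sit.

Still open, as far as these compounds go, is whether methoxycarbonyl to ethoxycarbonyl changes growth inhibition at all on the shared core of compound 3 and compound 4.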